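Swapping fluoro for methoxy on the pendant phenyl ring

The compounds below may be only part of what the source reports. "The series", "measured", "known", "first", "only" and "open" are said of these compounds alone.

Compound 2 `C#CCNC1CCc2c(SCCc3cccc(F)c3)cccc21` gives 4300 nM in an assay on isolated protein for inhibition of Amine oxidase [flavin-containing] B (Homo sapiens) (a higher number here means a weaker inhibitor, a lower number a stronger inhibitor), the lower of the two numbers measured, with compound 1 `C#CCNC1CCc2c(SCCc3ccc(C)cc3)cccc21` at 25800 nM. Compound 3 `C#CCNC1CCc2c(SCCc3cccc(OC)c3)cccc21` is not yet measured; it differs from compound 2 by methoxy in place of fluoro on an aromatic carbon. Within the data shown here, the only measured step that speaks to this position is a 6.0-fold lower number from compound 1 to compound 2 (0.78 log units; beyond the scatter), which shows that the substituent on this ring matters, but it does not separate the substituent from its position. The expectation for compound 3 is therefore a small shift toward a weaker value, a 1.6-fold higher number from compound 2 to compound 3 (0.21 log units; within the scatter), giving an estimate of 7000 nM with a range from 1500 nM to 30000 nM.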

Compound 3, half-maximal inhibitory concentration: 28700 nM
Compound 3: the middle estimate sits 4.1-fold (0.61 log units) below what was measured, within the range that was stated.
By their numbers in this assay, from the lowest: compound 2; then compounds 1 and 3 (each within the scatter of the next).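

In this assay, methoxy in place of fluoro on the same aromatic carbon gives a 6.7-fold higher number from compound 2 to compound 3 (0.82 log units; beyond the scatter), so this change alone moves the number, which the earlier step, with both substituent and position altered, could not show. The step of a 1.1-fold higher number from compound 1 to compound 3 (0.05 log units; within the scatter) leaves 3-methoxyphenyl and 4-methylphenyl indistinguishable, so among these three compounds only the 3-fluorophenyl of compound 2 stands apart. As far as these compounds go, how chloro, hydroxyl or an amine on this same aromatic carbon would compare with fluoro remains open. No evidence is available on what lies behind these differences.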